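Iodine for Bromine on a Weak Sigma-1 Binder

The source may hold more compounds than are shown below. What is called first, only, known or untested is meant among the compounds shown, and "the series" means these compounds.

Compound 1, `COc1cc2c(cc1OC)CN(CCCCNC(=O)c1cc(Br)cc(OC)c1OCCF)CC2`: 15300 nM
Compound 2, `COc1cc2c(cc1OC)CN(CCCCNC(=O)c1cc(Br)ccc1OCCF)CC2`: 1080 nM

Of the compounds shown here, two share a core and have been measured in an assay on membranes from brain for displacement of a labelled ligand from Sigma non-opioid intracellular receptor 1 (Cavia porcellus), with a stated time of 90 min; a higher number here means a weaker inhibitor, a lower number a stronger inhibitor. Compound 1 gives 15300 nM in this assay, the highest of the two numbers; its nearest neighbour, compound 2, gives 1080 nM, and the step of a 14-fold lower number from compound 1 to compound 2 (1.15 log units; beyond the scatter) comes with hydrogen in place of methoxy on an aromatic carbon.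

The unmeasured compound 3, `COc1cc2c(cc1OC)CN(CCCCNC(=O)c1cc(I)cc(OC)c1OCCF)CC2`, differs from compound 1 in one place: iodo in place of bromo on an aromatic carbon. Going by the values given here, no measured pair shows a change from one halogen to another, so the only step on record, a 14-fold lower number from compound 1 to compound 2 (1.15 log units; beyond the scatter), does not bear on this change; it concerns a different group on the same ring. With nothing to indicate a shift, compound 3 is expected to sit close to compound 1 in this assay, with any step likely inside the scatter. The estimate for compound 3 is 12000 nM, with a range from 4000 nM to 40000 nM, which corresponds to an expected step of a 1.3-fold lower number from compound 1 to compound 3 (0.11 log units; within the scatter).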

Compound 3, inhibition constant: 2150 nM
Compound 3: middle estimate off by 5.6-fold (0.75 log units), on the high side; the measured number lies below the stated range.
By their numbers in this assay, from the lowest: compounds 2 and 3 (each within the scatter of the next); then compound 1.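

In this assay the change to iodo on this aromatic carbon brings a 7.1-fold lower number from compound 1 to compound 3 (0.85 log units; beyond the scatter) and counts as a modest step. Going by these compounds alone, until now the only step on record concerned the methoxy group, so this is the first sign that the position para to the 2-fluoroethoxy group also responds to a change, here to the identity of the halogen. The swap replaces one heavy atom with one heavy atom and leaves the count of hydrogen-bond donors and acceptors and the net charge as they were, yet the step still lies beyond the scatter, and nothing in the available data accounts for it.

The compounds shown hold a single pair of halogens on a single background, so it stays open whether iodo in place of bromo would give a similar step on compound 2, which has hydrogen in place of the methoxy group. On these data alone, it also stays open how this position would respond to other groups, such as chloro, a nitrile or an amine, and whether any of them would continue the trend seen with iodo.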